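The source may report more compounds than this note shows. Statements on the series, on what has been measured and on what is new or still open speak of the compounds shown alone.

Measured so far in a functional assay on Caco-2 cells (Homo sapiens) for inhibition, read by sulforhodamine B assay, with a stated time of 72 h; on this read-out lower numbers stand for stronger inhibition and higher numbers for weaker inhibition:
Compound 1 `CCC(C)NC(=C\C(=O)/C=C/c1ccc(OC(C)=O)c(OC)c1)/C=C/c1ccc(OC(C)=O)c(OC)c1` gives 24000 nM.
Compound 2 `C=CCNC(=C\C(=O)/C=C/c1ccc(O)c(OC)c1)/C=C/c1ccc(O)c(OC)c1` gives > 25000 nM.
Compound 3 `CCC(C)NC(=C\C(=O)/C=C/c1ccc(O)cc1)/C=C/c1ccc(O)cc1` gives 5800 nM.

The value of compound 2 is a limit of this assay and not a number: it sits at the limit of > 25000 nM in this assay, at which 1 of the 3 values shown sits. Within the data shown here, compound 3 is the one with a number clearly stronger than that limit, while compound 1 gives a number close to it.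

Compound 4 `CCCCNC(=C\C(=O)/C=C/c1ccc(O)c(OC)c1)/C=C/c1ccc(O)c(OC)c1` differs from compound 2 by propyl in place of vinyl on a saturated chain carbon bound to an amine nitrogen. Among the measured compounds shown here, the three measured compounds offer no step that isolates this change, so the expected step of an at least 1.3-fold lower number from compound 2 to compound 4 (0.14 log units; that floor lies within the scatter) is a small one, not beyond the scatter, with a modest lean towards stronger inhibition. Compound 4 is estimated to give 18000 nM, with a range from 6000 nM to 50000 nM.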

Compound 4, half-maximal inhibitory concentration: 23800 nM
Estimate against measurement, compound 4: 1.3-fold (0.12 log units) below; measured number inside the range.
By their numbers in this assay, from the lowest: compound 3; then compounds 4 and 1 (each within the scatter of the next). At a limit, above all of these: compound 2.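

In this assay, among these compounds, changing allyl to butyl gives the first step at this position, an at least 1.0-fold lower number from compound 2 to compound 4 (0.02 log units; that floor lies within the scatter). Compound 2 stands at a limit of the assay and not at a number: the limit of > 25000 nM in this assay, at which 1 of the 4 values shown sits. The step is therefore only a floor, so this change shows no clear gain or loss.

As far as these compounds go, how far apart compound 2 and compound 4 truly lie remains open. So does the effect of a longer chain such as octyl, or of a chain ending in an amine or a carboxylic acid.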